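Two Hydroxylated Diterpenoid Acids and an Epimeric Relative

A few compounds are considered here, and "the series" means these few. Any claim that something is new, unique, unknown or untested is made for them only; others in the source may bear on it.

Measured compounds:
compound 1 `C=CC(=C)[C@@H](O)C[C@H]1C(=C)CC[C@@H]2[C@]1(C)CCC[C@]2(C)C(=O)O`, > 40000 nM
compound 2 `C=C[C@@](C)(O)CC[C@H]1C(=C)CC[C@@H]2[C@]1(C)CCC[C@]2(C)C(=O)O`, > 40000 nM

Compound 2 `C=C[C@@](C)(O)CC[C@H]1C(=C)CC[C@@H]2[C@]1(C)CCC[C@]2(C)C(=O)O` was tested in a functional assay on A549 cells (Homo sapiens) for cytotoxicity, read by MTT assay, with a stated time of 48 h; a higher number here means a weaker inhibitor, a lower number a stronger inhibitor. In this assay compound 2 gives > 40000 nM, which is a limit of the assay and not a number. Compound 1 `C=CC(=C)[C@@H](O)C[C@H]1C(=C)CC[C@@H]2[C@]1(C)CCC[C@]2(C)C(=O)O` likewise gives > 40000 nM in this assay, again a limit rather than a number. The step that the two limits leave unreadable from compound 1 to compound 2 therefore cannot be read, as both values sit at the limit of > 40000 nM in this assay, at which 2 of the 2 values shown sit.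

Compound 3 `C=CC(=C)[C@H](O)C[C@H]1C(=C)CC[C@@H]2[C@]1(C)CCC[C@]2(C)C(=O)O` differs from compound 2 in one place: a group of 6 heavy atoms (5 carbon, 1 oxygen; no ring) in place of a group of 6 heavy atoms (5 carbon, 1 oxygen; no ring), on a saturated chain carbon bound to a saturated ring carbon. Within the data shown here, the only measured step bearing on this position, a step that the two limits leave unreadable from compound 1 to compound 2, is unreadable, so no direction beyond the scatter can be expected. Compound 3 is estimated at 60000 nM, with a range from 25000 nM to 200000 nM, and the step that the limit leaves unreadable from compound 2 to compound 3 is expected to be none beyond the scatter, most probably again reported only as a limit.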

Compound 3, half-maximal inhibitory concentration: > 40000 nM
Compound 3 was reported as a limit; the forecaster's own chance of this, stated with the estimate: 80%; the middle value lies beyond the limit too.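

Compound 3 gives only a limit too, so no step among compound 1, compound 2 and compound 3 can be read: the limit of > 40000 nM in this assay, at which 3 of the 3 values shown sit.

Any ranking of these compounds in this assay stays open, as does whether the configuration at the saturated chain carbon matters: the fact that compounds 1 and 3 differ only in the configuration as drawn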